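Swapping an Amide for a Sulfonamide on a Long-Chain Threonine Amide

The source may report more compounds than this note shows. Statements on the series, on what has been measured and on what is new or still open speak of the compounds shown alone.

Compound 2 `C/C=C/C=C/C(=O)N[C@H](C(=O)NCCCCCCCCCCCCCCCCCC)[C@@H](C)O` gives 79600 nM in a functional assay on MCF7 cells (Homo sapiens) for cytotoxicity, read by MTT assay, with a stated time of 48 h (on this read-out lower numbers stand for stronger inhibition and higher numbers for weaker inhibition), the higher of the two numbers measured here. Its companion compound 1 `CCCCCCCCCCCCCCCCCCNC(=O)[C@@H](NC(=O)c1nccc2ccccc12)[C@@H](C)O` gives 30800 nM; the difference is a 2.6-fold higher number from compound 1 to compound 2 (0.41 log units; beyond the scatter). Compound 3 `CCCCCCCCCCCCCCCCCCNC(=O)[C@@H](NS(=O)(=O)c1cccs1)[C@@H](C)O` differs from compound 2 by (thiophen-2-yl)sulfonyl in place of (penta-1,3-dien-1-yl)carbonyl on an amine nitrogen. Among the compounds with values here, no measured step exchanges a carbonyl for a sulfonyl, so the one step available only shows that an aromatic ring at this position went with a lower number than the open chain. Compound 3 is therefore expected to give 40000 nM, with a range from 12000 nM to 130000 nM. The expected step is a 2.0-fold lower number from compound 2 to compound 3 (0.30 log units; within the scatter).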

Compound 3, half-maximal inhibitory concentration: > 200000 nM
Compound 3: a limit, no number (the forecaster's own chance of this, stated with the estimate: 15%); middle value at least 5.0-fold (0.69 log units) from the limit.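

Compound 3 gives a limit, not a number: the limit of > 200000 nM in this assay, at which 1 of the 3 values shown sits.
Putting (thiophen-2-yl)sulfonyl on this amine nitrogen gives an at least 2.5-fold higher number from compound 2 to compound 3 (0.40 log units; beyond the scatter) in place of (penta-1,3-dien-1-yl)carbonyl, and an at least 6.4-fold higher number from compound 1 to compound 3 (0.81 log units; beyond the scatter) in place of (isoquinolin-1-yl)carbonyl.
An aromatic ring at this position therefore does not go with a lower number in every case, as compound 3 carries one and sits above both carbonyl compounds.

Ring and linking group change together in these steps, so their shares cannot be told apart. A (thiophen-2-yl)carbonyl group or an (isoquinolin-1-yl)sulfonyl group on this nitrogen would separate them.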